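Benzyloxy for bromo on a dichalcone core

This account rests on a few compounds, and the source may have more. Where it says the series, first, only, none or still open, it means among the compounds named here.

Compound 1 `Cc1cc(O)c(C(=O)/C=C/c2ccc(F)cc2)c(-c2ccc(Br)cc2)c1C(=O)/C=C/c1ccc(F)cc1` was tested in a functional assay on HeLa cells (Homo sapiens) for cytotoxicity, read by MTT assay, with a stated time of 24 h (on this read-out higher numbers stand for weaker inhibition and lower numbers for stronger inhibition), and gave "not active" (no number reported), so no single number stands for it; it is one of two entries in this set without a number. Two related compounds share its core. Among the compounds with values here, compound 2 `Cc1cc(O)c(C(=O)/C=C/c2ccc(Br)cc2)c(-c2ccccc2)c1C(=O)/C=C/c1ccc(Br)cc1` is the only member with a figure in this assay, where compound 2 gives 33500 nM. Compound 3 `Cc1cc(O)c(C(=O)/C=C/c2ccccc2)c(-c2ccccc2)c1C(=O)/C=C/c1ccccc1` returns, in this assay, "not active" (no number reported), the second entry without a number.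

Compound 4 `Cc1cc(O)c(C(=O)/C=C/c2ccc(F)cc2)c(-c2ccc(OCc3ccccc3)cc2)c1C(=O)/C=C/c1ccc(F)cc1` differs from compound 1 in one place: benzyloxy in place of bromo on an aromatic carbon. The change sits on an aromatic carbon of a six-membered aromatic ring of carbon only, para to a large group.

Within the data shown here, no step between measured compounds is available, and none of the three measured compounds differs from another in exactly one place, so no calibration of this kind of exchange exists within the set. Given that compound 1 gave "not active" (no number reported) and compound 3 gave "not active" (no number reported), the author expects any shift in this assay for compound 4 to be small and of unknown direction, most likely not beyond the scatter, with a strong chance that no number is reported again. Compound 4 is therefore estimated at 45000 nM, within a range from 15000 nM to 150000 nM.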

Compound 4, half-maximal inhibitory concentration: 25000 nM
Compound 4: middle estimate off by 1.8-fold (0.26 log units), on the high side; low and high end bracket the measured number.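

No step can be read from compound 1 to compound 4 in this assay, since compound 1 gives "not active" (no number reported) and so offers no number to start from. The compounds shown leave open how large the exchange of bromo for benzyloxy is, and in which direction it acts. No evidence at hand bears on this result.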